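The source may report more compounds than this note shows. Statements on the series, on what has been measured and on what is new or still open speak of the compounds shown alone.

Measured so far in a functional assay on B16 cells (Mus musculus) for inhibition, with a stated time of 72 h; on this read-out higher numbers stand for weaker inhibition and lower numbers for stronger inhibition:
compound 1 `S=C1NCCN1Cc1ccccc1` reads > 10000 nM (a limit)
compound 2 `Cc1ccc(CN2CCCNC2=S)cc1` reads 5100 nM (a number)

Among the measured compounds shown here, compound 2 carries the only number so far, and the other reading is a limit, as the limit of > 10000 nM in this assay, at which 1 of the 2 values shown sits, records. Compound 3 `CC(C)c1ccc(CN2CCCNC2=S)cc1` is the next to be read, with isopropyl in place of methyl on an aromatic carbon, para to a group of 8 heavy atoms: isopropyl in place of methyl on an aromatic carbon is the whole difference. For the measured compounds named here, no measured step shows what a change of this kind does in this assay, so the expectation starts from compound 2 at 5100 nM and stays close to it. The expected 1.7-fold lower number from compound 2 to compound 3 (0.23 log units; within the scatter) is small, about the size of the usual scatter, and leans slightly toward stronger inhibition. For compound 3 the estimated value is 3000 nM with an expected range of 1000 nM to 9000 nM in this read-out.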

Compound 3, half-maximal inhibitory concentration: 800 nM
Compound 3: middle estimate off by 3.8-fold (0.57 log units), on the high side; measured number outside the range, below it.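

In this assay, among the compounds shown here, isopropyl in place of methyl on the aromatic carbon para to a group of 8 heavy atoms gives a 6.4-fold lower number from compound 2 to compound 3 (0.80 log units; beyond the scatter), the first measured step. This position therefore responds to a change of alkyl group, and on this single pair the group of 3 heavy atoms goes with stronger inhibition than the group of 1 heavy atom. Nothing among the data shown accounts for the size of this step.

On these data alone, whether inhibition keeps strengthening with tert-butyl or a longer chain such as n-butyl on this carbon stays open, as does whether a chlorine, an amine or a carboxylic acid there would read anywhere near compound 3. As far as these compounds go, it is also open whether the same exchange of methyl for isopropyl would give a step of similar size on the core of compound 1.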